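Methoxy to Fluoro on the Aryl Cap of Compound 3

This account rests on a few compounds, and the source may have more. Where it says the series, first, only, none or still open, it means among the compounds named here.

Measured so far:
compound 1, `Fc1ccc(Nc2cc(Nc3ccc(Oc4ccncc4-c4cccnc4)c(F)c3)ncn2)cc1`, 710 nM
compound 2, `Cn1c(=O)c(C(=O)Nc2ccc(Oc3ccncc3-c3cccnc3)c(F)c2)nn(-c2ccc(F)c(Cl)c2)c1=O`, 12500 nM
compound 3, `COc1ccc(-n2nc(C(=O)Nc3ccc(Oc4ccncc4-c4cccnc4)c(F)c3)c3ccccc3c2=O)cc1`, 6800 nM

All three were run in a functional assay on A549 cells (Homo sapiens) for cytotoxicity, read by MTT assay, with a stated time of 72 h; on this read-out higher numbers stand for weaker inhibition and lower numbers for stronger inhibition. Compound 3 holds the second highest of the three numbers; its nearest neighbour is compound 2, whose value lies within the scatter of it, and its furthest is compound 1, whose value is lower and beyond the scatter. Compound 4, `O=C(Nc1ccc(Oc2ccncc2-c2cccnc2)c(F)c1)c1nn(-c2ccc(F)cc2)c(=O)c2ccccc12`, has not been measured. It differs from compound 3 in one place: fluoro in place of methoxy on an aromatic carbon. For the measured compounds named here, no measured pair isolates this change, so its size is not fixed by the data. The expected step in this assay is a 1.1-fold lower number from compound 3 to compound 4 (0.05 log units; within the scatter), with no direction clearly beyond the scatter. Compound 4 is therefore estimated at 6000 nM, within a range of 2500 nM to 15000 nM.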

Compound 4, half-maximal inhibitory concentration: 820 nM
Estimate against measurement, compound 4: 7.3-fold (0.86 log units) above; measured number outside the range, below it.
By their numbers in this assay, from the lowest: compounds 1 and 4 (each within the scatter of the next); then compounds 3 and 2 (each within the scatter of the next).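

In this assay, replacing 4-methoxyphenyl with 4-fluorophenyl on the cap gives an 8.3-fold lower number from compound 3 to compound 4 (0.92 log units; beyond the scatter) and shows that this single position can move the number beyond the scatter. The earlier compounds shown here differ from one another in more than one place, so they could not show this. No measurement here explains the step.

A hydrogen, a chloro or an amine at this place would help show whether the step follows from gaining fluoro or from losing methoxy. As far as these compounds go, how the number responds to a longer alkoxy chain also remains open.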